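The compounds below may be only part of what the source reports. "The series", "measured", "known", "first", "only" and "open" are said of these compounds alone.

Going by the values given here, in an assay on HEK293 cells for displacement of a labelled ligand from NPC1-like intracellular cholesterol transporter 1 (Homo sapiens) (a higher number here means a weaker inhibitor, a lower number a stronger inhibitor), compound 1 `CC(C)(C)c1ccc(C(=O)N2CCC3(CC2)C(=O)N(CC(=O)NCCO)CN3c2ccccc2)cc1` gives 1000 nM, the lowest of the three numbers measured so far. Compound 3 `O=C(CN1CN(c2ccccc2)C2(CCN(C(=O)c3ccc(C4CCCCC4)cc3)CC2)C1=O)N1CCCCC1` gives 1100 nM, a number that sits within the scatter of compound 1, so the two cannot be ranked against each other. Among the compounds with values here, compound 2 `CCC1CCCN(C(=O)CN2CN(c3ccccc3)C3(CCN(C(=O)c4ccc(C5CCCCC5)cc4)CC3)C2=O)C1` gives 2600 nM, and only this gap to compound 1 lies beyond the scatter. Within the data shown here, the single step measured between two compounds that differ in one place is a 2.4-fold lower number from compound 2 to compound 3 (0.37 log units; beyond the scatter), a change of hydrogen for ethyl on a saturated ring carbon.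

Compound 4 `CC1(C)CC(OC(=O)CN2CN(c3ccccc3)C3(CCN(C(=O)c4ccc(C(C)(C)C)cc4)CC3)C2=O)CC(C)(C)N1` differs from compound 1 in (2,2,6,6-tetramethylpiperidin-4-yl)oxy in place of (2-hydroxyethyl)amino on a carbonyl carbon. Among the measured compounds shown here, the change sits on a carbonyl carbon whose other neighbour is a saturated chain carbon, a position that no measured step touches. The step from compound 2 to compound 3 was modest and concerns a different part of the molecule, so it gives no direction for this change. With nothing measured that bears on it, the safest expectation is no step beyond the scatter. For compound 4 the expected step is therefore no change at the digits printed from compound 1 to compound 4 (within the scatter). Compound 4 is estimated at 1000 nM, with a range from 250 nM to 4000 nM to reflect the lack of any guiding measurement.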

Compound 4, half-maximal inhibitory concentration: 1300 nM
The estimate for compound 4 lay 1.3-fold (0.11 log units) below the measured number, within the range that was stated.
By their numbers in this assay, from the lowest: compounds 1, 3, 4 and 2 (each within the scatter of the next, the first and the last beyond it).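

In this assay, going by these compounds alone, replacing (2-hydroxyethyl)amino with (2,2,6,6-tetramethylpiperidin-4-yl)oxy gives a 1.3-fold higher number from compound 1 to compound 4 (0.11 log units; within the scatter) and so no step that can be read as real. Within the data shown here, this is the first measured change on this carbonyl carbon, and it shows that, for this one pair, a group of 11 heavy atoms with a six-membered non-aromatic ring can stand where a ringless group of 4 heavy atoms stood, with the number staying within the scatter. Nothing available explains why the two compounds cannot be told apart here, so the result stands as an observation only.

The swap alters two things at once, the atom that joins the group to the carbonyl carbon and the group beyond that atom, so the pair cannot show what either does alone, and a compound carrying (2-hydroxyethyl)oxy or (2,2,6,6-tetramethylpiperidin-4-yl)amino at this place would begin to separate them. Also open, on these data alone, is how a carboxylic acid, formed by a plain hydroxyl on this carbonyl carbon, or a small dimethylamino group would read in this assay.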